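A few compounds are considered here, and "the series" means these few. Any claim that something is new, unique, unknown or untested is made for them only; others in the source may bear on it.

Of the compounds shown here, three built on one shared core have been tested in a functional assay on K562 cells (Homo sapiens) for antiproliferative activity, read by MTT assay; on this read-out higher numbers stand for weaker inhibition and lower numbers for stronger inhibition. Compound 1 `CCCCOC(=O)N1CCCc2cc(S(=O)(=O)N3CC(c4ccccc4)NC3=O)ccc21` gives 3680 nM, compound 2 `O=C(OCCCl)N1CCCc2cc(S(=O)(=O)N3CC(c4ccccc4)NC3=O)ccc21` gives 10600 nM, and compound 3 `O=C(CCl)N1CCCc2cc(S(=O)(=O)N3CC(c4ccccc4)NC3=O)ccc21` gives 1100 nM, the lowest number of the three. Compound 4 `O=C(NC1CCCCC1)N1CCCc2cc(S(=O)(=O)N3CC(c4ccccc4)NC3=O)ccc21` has not yet been measured. It keeps the shared core and differs from compound 3 in one place, where cyclohexylamino stands in place of chloromethyl on a carbonyl carbon: cyclohexylamino in place of chloromethyl on a carbonyl carbon.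

Among the compounds with values here, no measured compound carries cyclohexylamino, so the evidence is indirect. Two measured steps change the group at this same carbonyl carbon: a 3.3-fold lower number from compound 1 to compound 3 (0.52 log units; beyond the scatter), and a 9.6-fold lower number from compound 2 to compound 3 (0.98 log units; beyond the scatter). Both replace an oxygen-linked group with chloromethyl, and both lower the number. A third step, a 2.9-fold higher number from compound 1 to compound 2 (0.46 log units; beyond the scatter), shows that the number also moves when only the chain on that oxygen changes, so the size of any new step is hard to pin down.

Leaving chloromethyl has so far meant a higher number, so a modest rise is expected in this assay. The expected step is a 3.6-fold higher number from compound 3 to compound 4 (0.56 log units; beyond the scatter). For compound 4 the estimated value is 4000 nM, with an expected range from 1200 nM to 13000 nM.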

Compound 4, half-maximal inhibitory concentration: 813 nM
Estimate against measurement, compound 4: 4.9-fold (0.69 log units) above, and the stated range ends above it.
By their numbers in this assay, from the lowest: compounds 4 and 3 (each within the scatter of the next); then compound 1; then compound 2.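

In this assay the step of a 1.4-fold lower number from compound 3 to compound 4 (0.13 log units; within the scatter) lies within the scatter, so compound 3 and compound 4 cannot be told apart, even though cyclohexylamino brings a six-membered carbon ring and a hydrogen-bond donor that chloromethyl lacks. Within the data shown here, compound 1, compound 2 and compound 3 left chloromethyl as the only group at this carbonyl carbon with a number near this level, and the new result shows that chloromethyl is not required for it. Cyclohexylamino also stands clear of both oxygen-linked groups, with a 4.5-fold lower number from compound 1 to compound 4 (0.66 log units; beyond the scatter) against butoxy and a 13-fold lower number from compound 2 to compound 4 (1.12 log units; beyond the scatter) against 2-chloroethoxy, and nothing available here explains these steps.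

The compounds shown leave open whether the amide hydrogen or the ring counts at this position, a question that dimethylamino, which has no such hydrogen, and hexylamino, an open chain, could each help to separate. They also leave open how a smaller ring on the same nitrogen, such as cyclopropyl, or an aromatic ring such as phenyl, would compare with cyclohexyl.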